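This account rests on a few compounds, and the source may have more. Where it says the series, first, only, none or still open, it means among the compounds named here.

Working notes on the series. All compounds share the core of compound 1 `Cc1cccc(Cl)c1NC(=O)CN1CCN(c2nnc(Cc3ccncc3)c3ccccc23)CC1` and differ only in the aryl group on the amide nitrogen. In a functional assay on MDA-MB-231 cells (Homo sapiens) for cytotoxicity, read by MTT assay, with a stated time of 72 h (on this read-out higher numbers stand for weaker inhibition and lower numbers for stronger inhibition), compound 1 gives 2670 nM, the low end of the three numbers, though compound 3 `O=C(CN1CCN(c2nnc(Cc3ccccc3)c3ccccc23)CC1)Nc1cccc(Br)c1` with 3880 nM lies within the scatter of compound 1; compound 2 `Cc1ccc(F)cc1NC(=O)CN1CCN(c2nnc(Cc3ccccc3)c3ccccc23)CC1` gives 19200 nM, beyond the scatter. Among the compounds with values here, the one single-point step measured is a 4.9-fold lower number from compound 2 to compound 3 (0.69 log units; beyond the scatter), showing that exchange of the aryl group alone moves the number modestly. Compound 4 `Cc1ccc(NC(=O)CN2CCN(c3nnc(Cc4ccncc4)c4ccccc34)CC2)c(C)c1` differs from compound 1 by 2,4-dimethylphenyl in place of 2-chloro-6-methylphenyl on an amide-type nitrogen. Within the data shown here, no measured step carries this exact pair of groups, so the aryl step seen is the only guide; compound 4 is expected to stay near compound 1, with a somewhat higher number, a 1.5-fold higher number from compound 1 to compound 4 (0.18 log units; within the scatter). The estimate for compound 4 is 4000 nM, range 1500 nM to 12000 nM.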

Compound 4, half-maximal inhibitory concentration: 240 nM
Estimate against measurement, compound 4: 17-fold (1.22 log units) above; the measured number lies below the stated range.
By their numbers in this assay, from the lowest: compound 4; then compounds 1 and 3 (each within the scatter of the next); then compound 2.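

In this assay, an 11-fold lower number from compound 1 to compound 4 (1.05 log units; beyond the scatter), so exchange of the aryl group on this amide-type nitrogen can produce a large step, where the earlier aryl step was only modest. The two groups have the same count of heavy atoms, one six-membered aromatic ring of carbon only, no hydrogen-bond donors or acceptors and no net charge, so these counts do not separate them. Nothing measured here bears on the cause of this step.

Open, from the compounds shown here alone, is whether the step tracks the chlorine or the arrangement of the substituents on the ring. A 2,6-dimethylphenyl group on the same nitrogen would separate these two readings.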